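This account rests on a few compounds, and the source may have more. Where it says the series, first, only, none or still open, it means among the compounds named here.

Compound 1 `O=C(NNC(=O)c1cccc(Cl)c1)c1ccc(NS(=O)(=O)c2cnc(O)nc2O)cc1` gives 4160 nM in a functional assay on MDA-MB-231 cells (Homo sapiens) for antiproliferative activity, read by MTT assay, with a stated time of 24 h; a higher number here means a weaker inhibitor, a lower number a stronger inhibitor. Compound 2 `O=C(NNC(=O)c1ccccc1F)c1ccc(NS(=O)(=O)c2cnc(O)nc2O)cc1` reaches only > 20000 nM in this assay, which is a limit of the assay rather than a number, as noted under (the limit of > 20000 nM in this assay, at which 1 of the 3 values shown sits). The change 2-fluorophenyl in place of 3-chlorophenyl on a carbonyl carbon therefore produced an at least 4.8-fold higher number from compound 1 to compound 2 (0.68 log units; beyond the scatter). Compound 3 `O=C(NNC(=O)c1ccccc1NS(=O)(=O)c1cnc(O)nc1O)c1cccc(Cl)c1` is built from the same atoms as compound 1, joined differently; the difference between the two cores is not broken down here. In this assay compound 3 gives 4420 nM.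

Compound 4 `O=C(NNC(=O)c1ccccc1NS(=O)(=O)c1cnc(O)nc1O)c1ccccc1F` has not yet been measured in this assay. It differs from compound 3 by 2-fluorophenyl in place of 3-chlorophenyl on a carbonyl carbon, the same change that separates compound 1 from compound 2. Because an at least 4.8-fold higher number from compound 1 to compound 2 (0.68 log units; beyond the scatter) was a weakening step, a comparable weakening, a 5.7-fold higher number from compound 3 to compound 4 (0.75 log units; beyond the scatter), is expected from compound 3 to compound 4. Compound 4 is thus estimated at 25000 nM in this assay, quite possibly reported only as a limit.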

Compound 4, half-maximal inhibitory concentration: > 20000 nM
Compound 4 was reported as a limit (the forecaster's own chance of this, stated with the estimate: 65%); the middle value does not contradict the limit.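

In this assay compound 4 gives > 20000 nM, which is a limit of the assay and not a number. The change to 2-fluorophenyl in place of 3-chlorophenyl on a carbonyl carbon weakened the second core as well, with an at least 4.5-fold higher number from compound 3 to compound 4 (0.65 log units; beyond the scatter), and the two steps stand side by side: the same change on two cores in this assay, an at least 4.8-fold higher number (0.68 log units; beyond the scatter) from compound 1 to compound 2 and an at least 4.5-fold higher number (0.65 log units; beyond the scatter) from compound 3 to compound 4; the limit leaves it open whether they differ. The direction of the change thus carried over from one core to the other, but the full size of the loss on either core is not shown: the limit of > 20000 nM in this assay, at which 2 of the 4 values shown sit.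

As far as these compounds go, what 3-fluorophenyl or 2-chlorophenyl would give on either core stays open, so the effects of the halogen and of its position cannot be told apart. How an amine or a carboxylic acid on that ring would fare is open as well.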